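The source may hold more compounds than are shown below. What is called first, only, known or untested is meant among the compounds shown, and "the series" means these compounds.

In an assay on microsomes from brain (strain Sprague-Dawley) for inhibition of heme oxygenase 2 (Rattus norvegicus), read by spectrophotometry, with a stated time of 60 min (on this read-out higher numbers stand for weaker inhibition and lower numbers for stronger inhibition), compound 1 `Brc1cccc(OCCCCCCn2ccnc2)c1` gives 41000 nM, compound 2 `Clc1ccc2sc(SCCCCCn3ccnc3)nc2c1` gives 900 nM, and compound 3 `O=[N+]([O-])c1ccc(OCCCn2cncn2)cc1` gives 44700 nM. Compound 3 thus shows the highest of the three numbers: the number for compound 1 lies within the scatter of it, while the number for compound 2 lies far beyond it. Compound 4 `O=[N+]([O-])c1ccc(OCCCCn2cncn2)cc1` differs from compound 3 in one place, with (1H-1,2,4-triazol-1-yl)methyl in place of 1H-1,2,4-triazol-1-yl on a saturated chain carbon, three bonds along the chain from an oxygen on an aromatic ring, so the chain between the aromatic oxygen and the triazole grows by one carbon. For the measured compounds named here, no measured pair shows such a step, so the expected step of a 1.8-fold lower number from compound 3 to compound 4 (0.25 log units; within the scatter) is a guess, leaning toward a somewhat lower number, yet possibly within the scatter. Compound 4 is therefore estimated at 25000 nM, within a range from 8000 nM to 80000 nM.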

Compound 4, half-maximal inhibitory concentration: 41700 nM
Beside the measured number, compound 4's estimate is 1.7-fold (0.22 log units) below it; measured number inside the range.
By their numbers in this assay, from the lowest: compound 2; then compounds 1, 4 and 3 (each within the scatter of the next).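

In this assay, for the compounds shown here, the first step at this position, (1H-1,2,4-triazol-1-yl)methyl in place of 1H-1,2,4-triazol-1-yl on a saturated chain carbon, gives a 1.1-fold lower number from compound 3 to compound 4 (0.03 log units; within the scatter). At this chain length, then, the added carbon leaves the two compounds indistinguishable in this assay, a reading that rests on this single pair. Nothing at hand offers an explanation for this result. Still open, on these data alone, is whether a longer chain would separate from these two compounds, and whether an imidazole in place of the triazole, or an amine in place of the nitro group, would shift the number on this core.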